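Swapping the chloro-indazole for an aza-bicycle on the urea

The source may report more compounds than this note shows. Statements on the series, on what has been measured and on what is new or still open speak of the compounds shown alone.

Three ureas on a shared core have been measured in a functional assay on SGC-7901 cells (Homo sapiens) for cytotoxicity, read by MTT assay, with a stated time of 72 h; on this read-out lower numbers stand for stronger inhibition and higher numbers for weaker inhibition. Compound 1 `O=C(Nc1ccc(-n2ncc3c(C(F)(F)F)cccc32)cc1)Nc1ccc(Cl)c(C(F)(F)F)c1` gives only a limit, > 32000 nM, in this assay. Compound 2 `O=C(Nc1ccc(-n2ncc3c(Cl)cccc32)cc1)Nc1ccc(Cl)c(C(F)(F)F)c1` gives 4600 nM, the higher of the two numbers recorded, and compound 3 `O=C(Nc1ccc(-n2ncc3c(C(F)(F)F)cccc32)cc1)Nc1ccc(C(F)(F)F)cc1` gives 4000 nM, a value that sits within the scatter of compound 2. The step of an at least 6.9-fold lower number from compound 1 to compound 2 (0.84 log units; beyond the scatter) and the step of an at least 8.0-fold lower number from compound 1 to compound 3 (0.90 log units; beyond the scatter) are both at least modest, but neither is more than a lower bound, because compound 1 sits at the limit of > 32000 nM in this assay, at which 1 of the 3 values shown sits.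

Compound 4 `O=C(Nc1ccc(-n2ncc3ccncc32)cc1)Nc1ccc(Cl)c(C(F)(F)F)c1` differs from compound 2 in one place: a group of 9 heavy atoms (6 carbon, 3 nitrogen; one five-membered aromatic ring with 2 hetero atoms, one six-membered aromatic ring with 1 hetero atom) in place of a group of 10 heavy atoms (7 carbon, 2 nitrogen, 1 chlorine; one five-membered aromatic ring with 2 hetero atoms, one six-membered aromatic ring of carbon only), on an aromatic carbon. The 4-chloro-1H-indazol-1-yl group leaves, and a group of 9 heavy atoms with one six-membered aromatic ring holding 1 hetero atom enters, on the aromatic carbon para to a large group. Among the compounds with values here, only the step from compound 1 to compound 2 touches this position, and it replaces one substituent on that bicycle rather than exchanging the whole bicycle and dropping the chloro. Within the data shown here, no measured step therefore fixes the direction. The estimate for compound 4 is 6000 nM, in the range 1500 nM to 30000 nM, which means an expected step of a 1.3-fold higher number from compound 2 to compound 4 (0.12 log units; within the scatter), no more than the scatter in either direction.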

Compound 4, half-maximal inhibitory concentration: > 32000 nM
Compound 4: only a limit was reported; the forecaster's own chance of this, stated with the estimate: 25%; middle value at least 5.3-fold (0.72 log units) away from the limit.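

In this assay compound 4 returns only a limit, > 32000 nM. Within the data shown here, exchanging the 4-chloro-1H-indazol-1-yl group for the group whose six-membered aromatic ring holds 1 hetero atom, on the aromatic carbon para to a large group, gives an at least 6.9-fold higher number from compound 2 to compound 4 (0.84 log units; beyond the scatter), so the first measured exchange of the whole bicycle at this position goes clearly towards weaker inhibition and is not the neutral swap that the earlier compounds left possible. The true size of this step stays unknown because compound 4 sits at the ceiling of the read-out: the limit of > 32000 nM in this assay, at which 2 of the 4 values shown sit.

The exchange removes the chloro and puts a hetero atom into the six-membered ring in a single step, and the compounds shown do not tell which of these changes accounts for the loss, or whether both contribute. Also open, as far as these compounds go, is how this position responds to other substituents on the bicycle, such as a methoxy group or an amine in place of the chloro, and whether any of them gives stronger inhibition than compound 2 does.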